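The source may report more compounds than this note shows. Statements on the series, on what has been measured and on what is new or still open speak of the compounds shown alone.

Measured in an assay (strain Wistar) for displacement of a labelled ligand from adenosine receptor A1 (Rattus norvegicus), read by scintillation counting; on this read-out lower numbers stand for stronger inhibition and higher numbers for weaker inhibition:
compound 1 `O=C(Nc1nc(-c2ccccc2)nc2c1nnn2Cc1ccccc1)c1cccc([N+](=O)[O-])c1` gives 77 nM
compound 2 `COc1ccccc1C(=O)Nc1nc(-c2ccccc2)nc2c1nnn2Cc1ccccc1` gives 1520 nM
compound 3 `O=C(Nc1nc(-c2ccccc2)nc2c1nnn2Cc1ccccc1)C1CC1` gives 7.5 nM

Compound 2 stands weakest of the three: the steps to it are a 20-fold higher number from compound 1 to compound 2 (1.30 log units; beyond the scatter) and, going on to the cyclopropyl amide, a 200-fold lower number from compound 2 to compound 3 (2.31 log units; beyond the scatter). Compound 4 `O=C(Nc1nc(-c2ccccc2)nc2c1nnn2Cc1ccccc1)c1ccccc1F` differs from compound 2 by fluoro in place of methoxy on an aromatic carbon, so the 2-methoxyphenyl becomes a 2-fluorophenyl while the carbonyl and the rest of the shared core stay. Both measured steps replace the whole group on the carbonyl carbon, not a single substituent on that ring, so they show only that this position moves the number a great deal. A moderate step lower is expected, a 3.8-fold lower number from compound 2 to compound 4 (0.58 log units; beyond the scatter), with wide uncertainty. For compound 4 the estimate in this assay is 400 nM, ranging from 100 nM to 1500 nM.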

Compound 4, inhibition constant: 40 nM
The estimate for compound 4 lay 10-fold (1.00 log units) above the measured number, outside the stated range (below it).
By their numbers in this assay, from the lowest: compound 3; then compounds 4 and 1 (each within the scatter of the next); then compound 2.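

In this assay exchanging only methoxy for fluoro on the ring gives a 38-fold lower number from compound 2 to compound 4 (1.58 log units; beyond the scatter), so one substituent on this aromatic carbon can shift the number strongly, with the rest of the molecule unchanged. The 2-fluorophenyl amide still trails the cyclopropyl amide (a 5.3-fold higher number from compound 3 to compound 4 (0.73 log units; beyond the scatter)), and it cannot be told apart from the 3-nitrophenyl amide (a 1.9-fold lower number from compound 1 to compound 4 (0.28 log units; within the scatter)). Nothing given here explains the size of the fluoro-for-methoxy step. Still open, on these data alone, is how chloro, hydroxy or an amine would behave at this same place on the ring.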